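Benzyl-triazole chromenones: cytotoxicity remains at the assay limit

The compounds below may be only part of what the source reports. "The series", "measured", "known", "first", "only" and "open" are said of these compounds alone.

Measured compounds:
Compound 1, `O=c1ccoc2cc(OCc3cn(Cc4ccccc4)nn3)ccc12`: > 300000 nM
Compound 2, `O=c1ccoc2cc(OCc3cn(Cc4ccc(Cl)cc4)nn3)ccc12`: > 300000 nM

In an ADME assay on L02 cells (Homo sapiens) for cytotoxicity, read by MTT assay, with a stated time of 48 h (a higher number here means a weaker inhibitor, a lower number a stronger inhibitor), compound 1 gives only a limit of the assay, > 300000 nM. In this assay compound 2 likewise gives only a limit, > 300000 nM. Within the data shown here, the one measured step, a step that the two limits leave unreadable from compound 1 to compound 2, therefore has no readable size or direction; both values sit at the limit of > 300000 nM in this assay, at which 2 of the 2 values shown sit. Compound 3, `O=c1ccoc2cc(OCc3cn(Cc4cccc(Br)c4)nn3)ccc12`, has not yet been measured in this assay. It differs from compound 2 by 3-bromophenyl in place of 4-chlorophenyl on a saturated chain carbon bound to an aromatic nitrogen. Because the step that the two limits leave unreadable from compound 1 to compound 2 is unreadable, no size can be carried over from it, and on the numbers shown compound 2 stands only at a limit. The expected step for compound 3 is a number no higher from compound 2 to compound 3 (the limit leaves the size open), that is, none beyond the scatter. Compound 3 is therefore estimated at 300000 nM in this assay, with a range from 100000 nM to 900000 nM, and most probably again only a limit.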

Compound 3, half-maximal inhibitory concentration: > 300000 nM
Compound 3 ended at the assay's limit; the forecaster's own chance of this, stated with the estimate: 80%; the middle value sits exactly at the limit.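

No step among compound 1, compound 2 and compound 3 can be read in this assay, since all three values are limits: the limit of > 300000 nM in this assay, at which 3 of the 3 values shown sit.

The compounds shown leave open how large those steps are, and whether any substituent on the benzyl group would bring a value within the assay's range.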